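A Pyrrole in Place of Dimethoxyphenyl: Expected Cytotoxicity

The compounds below may be only part of what the source reports. "The series", "measured", "known", "first", "only" and "open" are said of these compounds alone.

Of the compounds shown here, two sharing one core have been measured in an ADME assay on the whole organism for cytotoxicity, with Artemia salina as the target, with a stated time of 24 h; on this read-out higher numbers stand for an effect only at larger amounts of compound and lower numbers for an effect already at smaller amounts. Compound 1 `COc1ccc(/C=C/C(=O)c2ccccc2NC(=O)NS(=O)(=O)c2ccc(C)cc2)cc1OC` carries a 3,4-dimethoxyphenyl group on a double-bonded chain carbon bound to a double-bonded chain carbon, and in this assay compound 1 gives 12.9 ug/mL, the highest of the two numbers. Compound 2 `Cc1ccc(S(=O)(=O)NC(=O)Nc2ccccc2C(=O)/C=C/c2cccc(Br)c2)cc1` holds a 3-bromophenyl at that place, and in this assay compound 2 gives 4.02 ug/mL. Going by the values given here, the only step available, a 3.2-fold lower number from compound 1 to compound 2 (0.51 log units; beyond the scatter), shows that exchanging the group at this place can move the number modestly and beyond the scatter.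

Compound 3 `Cc1ccc(S(=O)(=O)NC(=O)Nc2ccccc2C(=O)/C=C/c2ccc[nH]2)cc1` is not yet measured. It differs from compound 1 as follows: 1H-pyrrol-2-yl in place of 3,4-dimethoxyphenyl on a double-bonded chain carbon bound to a double-bonded chain carbon. Among the compounds with values here, this change sits at the same place as the one measured step, but the entering 1H-pyrrol-2-yl is not another six-membered aromatic ring of carbon only, so that step is only a loose guide. Because a 3.2-fold lower number from compound 1 to compound 2 (0.51 log units; beyond the scatter) lowered the number, a lowering of similar or smaller size is expected for compound 3, written as a 1.8-fold lower number from compound 1 to compound 3 (0.27 log units; within the scatter). In this assay compound 3 is therefore expected to give about 7 ug/mL, within a range from 3 ug/mL to 16 ug/mL.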

Compound 3, concentration for half-maximal effect: 32.1 ug/mL
The estimate for compound 3 lay 4.6-fold (0.66 log units) below the measured number; the measured number lies above the stated range.
By their numbers in this assay, from the lowest: compound 2; then compound 1; then compound 3.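

In this assay, the place on the double-bonded chain carbon bound to a double-bonded chain carbon turns out to work in both directions: 1H-pyrrol-2-yl in place of 3,4-dimethoxyphenyl gives a 2.5-fold higher number from compound 1 to compound 3 (0.40 log units; beyond the scatter) and so runs against the earlier step, which went down. Comparing the two entering groups directly gives an 8.0-fold higher number from compound 2 to compound 3 (0.90 log units; beyond the scatter) and makes this the largest step of the three, so the choice of group here decides whether an effect needs larger or smaller amounts of compound, and two six-membered rings of carbon only were not enough to reveal that range. Nothing at hand accounts for the direction of these steps.

The exchange from 3,4-dimethoxyphenyl to 1H-pyrrol-2-yl alters several things at once, among them the ring size, the number of heavy atoms and the presence of a ring hydrogen-bond donor, so the compounds shown cannot tell which of these goes with the higher number. From the compounds shown here alone, an unsubstituted phenyl, a furan-2-yl or a 1-methyl-1H-pyrrol-2-yl at this same place would separate these features, and it also remains open whether a basic amine on the ring would follow either direction.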